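Trimethoxyphenyl pyrazole chalcones: removing one methoxy group

The source may report more compounds than this note shows. Statements on the series, on what has been measured and on what is new or still open speak of the compounds shown alone.

Compound 2 `COc1ccc(C(=O)/C=C/c2cc(-c3cc(OC)c(OC)c(OC)c3)n[nH]2)cc1OC` in a functional assay on K562 cells (Homo sapiens) for cytotoxicity, read by sulforhodamine B assay, with a stated time of 48 h, tested at 0.01 uM (on this read-out lower numbers stand for a stronger effect and higher numbers for a weaker effect at the one concentration tested), gives 96%; compound 1 `COc1cc(-c2cc(/C=C/C(=O)c3ccc(N)cc3)[nH]n2)cc(OC)c1OC` gives 100%, and the two numbers lie within the scatter of each other. Going by the values given here, the one change already seen at the carbonyl-bound ring, a number 4 percentage points lower from compound 1 to compound 2 (within the scatter), did not move the read-out beyond the scatter. Compound 3 `COc1ccc(C(=O)/C=C/c2cc(-c3cc(OC)c(OC)c(OC)c3)n[nH]2)cc1` differs from compound 2 by hydrogen in place of methoxy on an aromatic carbon, again at that ring. Among the compounds with values here, with the single comparable step giving no shift, compound 3 is expected in this assay to read about 97%, between 88% and 105%. The expected step of a number 1 percentage points higher from compound 2 to compound 3 (within the scatter) is estimated as none beyond the scatter.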

Compound 3, a percentage reported as activity, at one concentration (the size of the read-out at that concentration, not a potency): 97%
Estimate against measurement, compound 3: no gap at the digits printed; the range from low to high includes it.
By their numbers in this assay, from the lowest: compounds 2, 3 and 1 (each within the scatter of the next).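

In this assay, going from 3,4-dimethoxyphenyl to 4-methoxyphenyl gives a number 1 percentage points higher from compound 2 to compound 3 (within the scatter), so removing this methoxy leaves the read-out unmoved at the one concentration tested. Methoxy in place of amino on the same ring gives a number 3 percentage points lower from compound 1 to compound 3 (within the scatter), which adds a direct comparison of these two groups and likewise shows no shift. No evidence is available to explain these results. Whether a carboxylic acid, a dimethylamino group or a longer alkoxy chain at this ring would move the read-out beyond the scatter stays open, as does any separation of these compounds at other concentrations.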